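A few compounds are considered here, and "the series" means these few. Any claim that something is new, unique, unknown or untested is made for them only; others in the source may bear on it.

Measured in an ADME assay on Vero cells (Chlorocebus sabaeus) for cytotoxicity, read by luminescence, with a stated time of 2 days; on this read-out lower numbers stand for higher toxicity in this test and higher numbers for lower toxicity in this test:

compound 1, `CCc1nc2ccccc2n1CCCCOc1ccc(C)cc1`: 14 uM
compound 2, `CCc1nc2ccccc2n1CCCCOc1ccc(C)c(C)c1`: 14 uM
compound 3, `CCc1nc2ccc(C)cc2n1CCCCNc1ccc(C)cc1`: 20 uM

Compound 1 and compound 2 differ by one change, (methyl in place of hydrogen on an aromatic carbon), and this change gave no change at the digits printed from compound 1 to compound 2 (within the scatter). Compound 3 carries a different core; how it differs from compound 1 is not broken down here. The values of compound 3 and of compound 1 lie within the usual scatter of each other, as do those of compound 3 and compound 2, so no order among the three can be read from them.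

Compound 4, `CCc1nc2ccc(C)cc2n1CCCCNc1ccc(C)cc1C`, has not yet been measured. It arises from compound 3 by methyl in place of hydrogen on an aromatic carbon. This is the same kind of change as that from compound 1 to compound 2, but the surroundings differ: there the new methyl sat ortho to a methyl group and meta to a large group, here it sits ortho to a large group and meta to a methyl group. Because no change at the digits printed from compound 1 to compound 2 (within the scatter), the step from compound 3 to compound 4 in this assay is expected to be small, no change at the digits printed from compound 3 to compound 4 (within the scatter). Compound 4 is therefore estimated at 20 uM, with a likely range from 10 uM to 40 uM.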

Compound 4, half-maximal toxic concentration: 20 uM
The estimate for compound 4 equals the measured number at the digits printed; measured number inside the range.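

In this assay, putting a methyl on the aromatic ring of compound 3 gave no change at the digits printed from compound 3 to compound 4 (within the scatter). The same change thus behaved alike on two cores, even though the new methyl sat in different surroundings in each pair, and the two steps agree: the same change on two cores in this assay, no change at the digits printed (within the scatter) from compound 1 to compound 2 and no change at the digits printed (within the scatter) from compound 3 to compound 4, 1.0-fold (0.00 log units) apart, within the scatter of two such steps. This shows that in these two pairs the added methyl left the half-maximal toxic concentration unmoved within the usual scatter, but two pairs cannot show that the change would stay silent on every core or at every place on the ring, and they give no reason for the result.

The compounds shown leave open whether a different group at this place, such as a chlorine atom, a methoxy group or a carboxylic acid, would shift the number. They also leave open what a shorter or longer chain between the core and the aromatic ring would do in this test.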